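The source may hold more compounds than are shown below. What is called first, only, known or untested is meant among the compounds shown, and "the series" means these compounds.

Three compounds share one core and differ only in the group attached to that core. Compound 3 `COc1ccc(F)cc1CNCCCNc1ccnc2cc(Cc3ccc(F)cc3Cl)ccc12` gives 23 10^-6 cm/s in an ADME assay for permeability, using PAMPA, with a stated time of 30 min, at pH 7.4; a higher number here means that the compound crosses the layer faster, a lower number that the compound crosses the layer more slowly. Compound 1 `COc1ccc(F)cc1CNCCCNc1ccnc2cc(CCC(C)C)ccc12` gives 23 10^-6 cm/s in this assay, and compound 2 `COc1cccc(CNCCCNc2ccnc3cc(Oc4ccc(F)cc4)ccc23)c1O` gives 317 10^-6 cm/s. Compound 3 thus stands level with compound 1, the two together at the bottom of the three numbers, while compound 2 sits far above both, beyond the scatter. Compound 4 `COc1ccc(F)cc1CNCCCNc1ccnc2cc(Oc3ccc(F)cc3)ccc12` has not yet been measured. It differs from compound 3 in one place: 4-fluorophenoxy in place of 2-chloro-4-fluorobenzyl on an aromatic carbon. Among the compounds with values here, one measured step bears on this site of the core, and it was flat: no change at the digits printed from compound 1 to compound 3 (within the scatter). Within the data shown here, compound 2 carries the same 4-fluorophenoxy group that enters in compound 4, yet its benzylamine end differs from that of compound 3, so no single step links it to compound 4. The estimated step is a 3.5-fold higher number from compound 3 to compound 4 (0.54 log units; beyond the scatter), an expected rise of uncertain size. Compound 4 is therefore expected to give about 80 10^-6 cm/s in this assay, within a range from 25 10^-6 cm/s to 300 10^-6 cm/s.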

Compound 4, apparent permeability: 317 10^-6 cm/s
The estimate for compound 4 lay 4.0-fold (0.60 log units) below the measured number; measured number above the stated range.
By their numbers in this assay, from the lowest: compounds 1 and 3 (each within the scatter of the next); then compounds 2 and 4 (each within the scatter of the next).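

At this aromatic carbon of the shared core, the group does matter in this assay: the earlier step between two carbon-attached groups was flat, but 4-fluorophenoxy in place of 2-chloro-4-fluorobenzyl gives a 14-fold higher number from compound 3 to compound 4 (1.14 log units; beyond the scatter) and 4-fluorophenoxy in place of isopentyl gives a 14-fold higher number from compound 1 to compound 4 (1.14 log units; beyond the scatter) in the same assay. Compounds 1 and 3 both attach their group through carbon, whereas compound 4 attaches it through oxygen, so the large rise so far goes with that oxygen link, although the rest of the group changes along with it. With 4-fluorophenoxy in place, the other end of the molecule can change from 2-hydroxy-3-methoxyphenyl to 5-fluoro-2-methoxyphenyl with no change at the digits printed from compound 2 to compound 4 (within the scatter) as the result.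

From the compounds shown here alone, whether the oxygen link or the loss of chlorine goes with the rise stays open, and a 4-fluorobenzyl group or an amine link at this carbon would help separate the two. No measurement shown here explains the rise.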